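The compounds below may be only part of what the source reports. "The series", "measured", "known", "first", "only" and "open" are said of these compounds alone.

Compound 1 `COc1ccc(S(=O)(=O)N2CCc3cccc(-c4ccc([N+](=O)[O-])cc4)c32)cc1`: 34 nM
Compound 2 `COc1ccc(S(=O)(=O)N2CCc3cccc(-c4ccncc4)c32)cc1`: 69.5 nM
Compound 3 `COc1ccc(S(=O)(=O)N2CCc3cccc(-c4ccc(C#N)cc4)c32)cc1`: 17.2 nM

All three share one core and differ only in the aromatic group attached to it. In a functional assay on MKN-45 cells (Homo sapiens) for inhibition, with a stated time of 72 h (on this read-out lower numbers stand for stronger inhibition and higher numbers for weaker inhibition), compound 1 gives 34 nM, the second highest of the three numbers; the step of a 2.0-fold lower number from compound 1 to compound 3 (0.30 log units; within the scatter) lies within the scatter, while a 2.0-fold higher number from compound 1 to compound 2 (0.31 log units; beyond the scatter) lies beyond it. Compound 4 `COc1ccc(S(=O)(=O)N2CCc3cccc(-c4cccs4)c32)cc1` differs from compound 1 by thiophen-2-yl in place of 4-nitrophenyl on an aromatic carbon. Within the data shown here, two measured steps bear on this change. Exchanging the whole 4-nitrophenyl for another aromatic ring gave a 2.0-fold higher number from compound 1 to compound 2 (0.31 log units; beyond the scatter), a modest loss; exchanging only nitro for cyano gave a 2.0-fold lower number from compound 1 to compound 3 (0.30 log units; within the scatter). Replacing the entire 4-nitrophenyl again therefore seems likely to cost a modest amount in this assay. Compound 4 is expected at 60 nM, between 25 nM and 150 nM, an expected 1.8-fold higher number from compound 1 to compound 4 (0.25 log units; within the scatter).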

Compound 4, half-maximal inhibitory concentration: 165 nM
For compound 4 the middle estimate is 2.8-fold (0.44 log units) below the measured one, outside the stated range (above it).
By their numbers in this assay, from the lowest: compounds 3 and 1 (each within the scatter of the next); then compound 2; then compound 4.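

In this assay, the five-membered thiophen-2-yl ring gives weaker inhibition than each six-membered ring tested here: a 4.9-fold higher number from compound 1 to compound 4 (0.69 log units; beyond the scatter), a 2.4-fold higher number from compound 2 to compound 4 (0.38 log units; beyond the scatter) and a 9.6-fold higher number from compound 3 to compound 4 (0.98 log units; beyond the scatter). Among these compounds, the last of these steps is larger than any among the earlier compounds, so the choice of ring at this position matters more than they suggested. No measurement here explains the change. Going by these compounds, it stays open whether the weaker inhibition goes with the smaller ring or with its sulfur, and how a furan-2-yl ring or a plain phenyl ring would compare.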